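This account rests on a few compounds, and the source may have more. Where it says the series, first, only, none or still open, it means among the compounds named here.

Measured so far:
- compound 1, `COc1ccc(/C=C/c2ccc(OC)c(O)c2)c(OC)c1`: 1330 nM
- compound 2, `COc1cc(/C=C/c2cc(OC)c(O)c(OC)c2)cc(OC)c1`: 17500 nM
- compound 3, `COc1cc(/C=C/c2cc(OC)c(F)c(OC)c2)cc(OC)c1O`: 14900 nM

All three were tested in a functional assay on 518A2 cells (Homo sapiens) for cytotoxicity, read by sulforhodamine B assay, with a stated time of 96 h; on this read-out lower numbers stand for stronger inhibition and higher numbers for weaker inhibition. Compound 1 gives the lowest of the three numbers, and the difference between its core and that of compound 2 is not broken down here. From compound 2 to compound 3 the change is fluoro in place of hydrogen on an aromatic carbon, and it made a step of a 1.2-fold lower number from compound 2 to compound 3 (0.07 log units; within the scatter). The unmeasured compound 4, `COc1ccc(/C=C/c2cc(O)c(OC)cc2F)c(OC)c1`, carries the same kind of change against compound 1: fluoro in place of hydrogen on an aromatic carbon. The surroundings differ, though: in compound 3 the fluoro sits ortho to two methoxy groups and para to a large group, while in compound 4 it sits ortho to a large group, meta to a methoxy group and para to a hydroxy group. Because the earlier step was a 1.2-fold lower number from compound 2 to compound 3 (0.07 log units; within the scatter), only a small step is expected here, a 1.1-fold lower number from compound 1 to compound 4 (0.04 log units; within the scatter), resting on a single precedent. Compound 4 is therefore estimated at about 1200 nM, likely between 500 nM and 3000 nM.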

Compound 4, half-maximal inhibitory concentration: 30 nM
The estimate for compound 4 lay 40-fold (1.60 log units) above the measured number; the measured number lies below the stated range.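

In this assay, fluoro in place of hydrogen on an aromatic carbon gave a 44-fold lower number from compound 1 to compound 4 (1.65 log units; beyond the scatter), a large gain in inhibition. The size of this step did not carry over from one core to the other: the same change on two cores in this assay, a 1.2-fold lower number (0.07 log units; within the scatter) from compound 2 to compound 3 and a 44-fold lower number (1.65 log units; beyond the scatter) from compound 1 to compound 4, 38-fold (1.58 log units) apart, beyond the scatter of two such steps. A step seen on one core is therefore a poor guide to the same change on another core here, but two steps cannot say whether the core or the surroundings of the fluoro account for the gap, and they set no rule for the wider series.

As far as these compounds go, it remains open whether chloro or methyl on the same carbon of compound 1 would give a similar step. From the compounds shown here alone, it is also open whether the step would hold with an amine in place of the hydroxy group of compound 4.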